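The compounds below may be only part of what the source reports. "The series", "measured", "known", "first", "only" and "open" are said of these compounds alone.

In a functional assay on MOLT-4 cells (Homo sapiens) for inhibition (a higher number here means a weaker inhibitor, a lower number a stronger inhibitor), compound 1 `O=C1/C(=C/c2ccc(Br)cc2)CCc2ccccc21` is reported only as a limit, > 500000 nM. Compound 2 `O=C1/C(=C/c2ccc(Br)cc2)CCCc2ccccc21` gives 54700 nM, and compound 3 `O=C1CCCCC/C1=C\c1ccc(Cl)cc1` gives 52600 nM. These two numbers lie within the scatter of each other, so compound 3 stands level with compound 2 among the measured numbers. Compound 4 `COc1ccc(/C=C2\CCCCCC2=O)cc1` carries methoxy in place of chloro on an aromatic carbon, para to a group of 9 heavy atoms: methoxy in place of chloro on an aromatic carbon. For the measured compounds named here, no measured pair shows this change on its own, so the expectation in this assay is of no shift beyond the scatter. The estimated step of a 1.1-fold lower number from compound 3 to compound 4 (0.02 log units; within the scatter) is expected to remain within that scatter. For compound 4 the expected value is 50000 nM, with an estimated range from 18000 nM to 140000 nM.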

Compound 4, half-maximal inhibitory concentration: 250000 nM
Estimate against measurement, compound 4: 5.0-fold (0.70 log units) below; measured number above the stated range.
By their numbers in this assay, from the lowest: compounds 3 and 2 (each within the scatter of the next); then compound 4. At a limit, above all of these: compound 1.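

In this assay, for the compounds shown here, methoxy in place of chloro on an aromatic carbon gives a 4.8-fold higher number from compound 3 to compound 4 (0.68 log units; beyond the scatter), so this position, unlike what the earlier compounds could show, responds to a single change, and here the change weakens inhibition. Compound 1 alone stands at a limit, and compound 4 still has a number short of it: the limit of > 500000 nM in this assay, at which 1 of the 4 values shown sits.

This single pair cannot separate the loss of chloro from the entry of methoxy. As far as these compounds go, how an amine or a carboxylic acid would fare at this position stays open, as does whether the same change holds on the core of compound 2.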